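The source may hold more compounds than are shown below. What is called first, only, known or untested is meant among the compounds shown, and "the series" means these compounds.

Compounds measured in a functional assay on the whole organism (strain Swiss albino) with Mus musculus as the target, with stated times of 30 min and 10 min, at a dose of 50 mg/kg by the oral route; on this read-out higher numbers stand for more inhibition at the one dose given (going by the name of the read-out) and lower numbers for less inhibition:

compound 1 `CC(=O)c1c(NNc2ccc(C)cc2)cc(C)oc1=O` gives 70.2%
compound 2 `CC(=O)c1c(NNc2ccc(Br)cc2)cc(C)oc1=O` gives 53.1%
compound 3 `Cc1cc2nn(-c3ccccc3)c(C)c2c(=O)o1` gives 50.2%

Compound 3 stands at the lower end of these three numbers. Its value lies within the scatter of compound 2, so no order can be read between those two, while compound 1 sits well above it, by a margin beyond the scatter. Compound 4 `Cc1ccc(-n2nc3cc(C)oc(=O)c3c2C)cc1` differs from compound 3 in one place: methyl in place of hydrogen on an aromatic carbon. The new methyl sits on the six-membered aromatic ring of carbon only that hangs from the shared core.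

Among the compounds with values here, only one measured step speaks to this ring. Between compound 1 and compound 2 the methyl on that ring was exchanged for bromo, and the number moved a number 17.1 percentage points lower from compound 1 to compound 2 (beyond the scatter). Within the data shown here, that step shows a methyl on this ring outscoring a bromo, but no measured pair shows a methyl against a plain hydrogen, so the direction for compound 4 is only suggested, not fixed. A small upward step in this assay is therefore expected, plausibly within the scatter.

The step from compound 3 to compound 4 is estimated to be a number 5.8 percentage points higher from compound 3 to compound 4 (within the scatter). Compound 4 is expected to give about 56%, with a range from 44% to 68%.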

Compound 4, a percentage reported as inhibition, in the whole organism at one dose (the size of the read-out at that dose, not a potency): 69.4%
Compound 4: middle estimate off by 13.4 percentage points, on the low side; measured number above the stated range.
By their numbers in this assay, from the lowest: compounds 3 and 2 (each within the scatter of the next); then compounds 4 and 1 (each within the scatter of the next).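

In this assay, the methyl on the six-membered aromatic ring of carbon only, para to a large group, can now be set directly against a plain hydrogen, and the number comes out as a number 19.2 percentage points higher from compound 3 to compound 4 (beyond the scatter). Within the data shown here, this is the first measured sign that adding a single methyl at this place can move the read-out by more than the usual scatter. Among these compounds, the only earlier step on this ring, a number 17.1 percentage points lower from compound 1 to compound 2 (beyond the scatter), compared methyl with bromo on a different core, so it showed that the choice of group matters but not what the methyl does relative to hydrogen. Nothing available explains why the methyl raises the number in this pair.

As far as these compounds go, it remains open whether the methyl step is specific to this core, as the core of compound 1 has no partner carrying hydrogen on this ring. From the compounds shown here alone, it is equally open how other groups at this place on the core of compound 3 would compare with methyl, such as a methoxy group, a chlorine atom, an amine or a longer chain like ethyl.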